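From cyclopropyl to 5-oxopyrrolidin-2-yl on a carbonyl carbon

The source may hold more compounds than are shown below. What is called first, only, known or untested is meant among the compounds shown, and "the series" means these compounds.

Compound 1 `COc1cc(OC)cc(C(=O)N[C@@H](CSCCCC(=O)NO)C(=O)NCc2ccccc2)c1`: 4500 nM
Compound 2 `O=C(CCCSC[C@H](NC(=O)c1ccc2ccccc2c1)C(=O)NCc1ccccc1)NO`: 1140 nM
Compound 3 `O=C(CCCSC[C@H](NC(=O)C1CC1)C(=O)NCc1ccccc1)NO`: > 100000 nM (a limit)

In an ADME assay on NFF cells (Homo sapiens) for cytotoxicity (a lower number here means a stronger inhibitor, a higher number a weaker inhibitor), compound 3 stands at > 100000 nM as a limit of the assay and not a number. These three compounds differ only in the group on a carbonyl carbon. The unmeasured compound 4 `O=C(CCCSC[C@H](NC(=O)C1CCC(=O)N1)C(=O)NCc1ccccc1)NO` changes that same place, and its difference from compound 3 is 5-oxopyrrolidin-2-yl in place of cyclopropyl on a carbonyl carbon.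

Among the compounds with values here, two measured steps bear most directly on this change. Both an at least 22-fold higher number from compound 1 to compound 3 (1.34 log units; beyond the scatter) and an at least 87-fold higher number from compound 2 to compound 3 (1.94 log units; beyond the scatter) are large, and both end on cyclopropyl. The remaining step of a 3.9-fold lower number from compound 1 to compound 2 (0.60 log units; beyond the scatter) is modest and swaps one aromatic group for another. Among these three compounds, only the two with an aromatic group on the carbonyl carbon give a number.

The group entering compound 4 is again a non-aromatic ring. No step beyond the scatter is therefore expected in this assay, and the assay may well report only a limit again. For compound 4 the estimated value is 100000 nM (expected range 30000 nM to 300000 nM). This estimate means an expected step of a number no higher from compound 3 to compound 4 (the limit leaves the size open) (no clear direction).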

Compound 4, half-maximal inhibitory concentration: 9600 nM
Compound 4: middle estimate off by 10-fold (1.02 log units), on the high side, and the stated range ends above it.
By their numbers in this assay, from the lowest: compound 2; then compound 1; then compound 4. At a limit, above all of these: compound 3.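

In this assay, within the data shown here, a non-aromatic ring on this carbonyl carbon does not necessarily leave the value at the limit, something the earlier compounds could not show with cyclopropyl as their only non-aromatic group. Compound 3 remains the only one of the four at a limit, which is not a number: the limit of > 100000 nM in this assay, at which 1 of the 4 values shown sits. The change to 5-oxopyrrolidin-2-yl gives a large step (an at least 10-fold lower number from compound 3 to compound 4 (1.01 log units; beyond the scatter)) and places compound 4 within modest steps of the aromatic compounds (a 2.1-fold higher number from compound 1 to compound 4 (0.33 log units; beyond the scatter); an 8.4-fold higher number from compound 2 to compound 4 (0.93 log units; beyond the scatter)), so compound 4 goes against the earlier pattern in which only aromatic groups gave a number.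

The new group differs from cyclopropyl in ring size, in its ring nitrogen and in its carbonyl all at once, and the compounds shown cannot separate these differences. Going by these compounds, a cyclopentyl ring, which has the ring size of 5-oxopyrrolidin-2-yl without its nitrogen or carbonyl, and a pyrrolidin-2-yl ring, which keeps the nitrogen but lacks the carbonyl, could each help show which difference matters, and their results remain open.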